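This account rests on a few compounds, and the source may have more. Where it says the series, first, only, none or still open, it means among the compounds named here.

The measured compounds, all read in a functional assay on SW480 cells (Homo sapiens) for cytotoxicity, read by MTT assay, with a stated time of 4 days; on this read-out lower numbers stand for stronger inhibition and higher numbers for weaker inhibition:

Compound 1 `Cc1c(O)ccc2c1[C@H](Cn1cc(-c3ccccn3)nn1)[C@@]13CC(=O)[C@@](C)(CC[C@@H]21)C3`: compound 1 gives > 20000 nM, which is a limit of the assay rather than a number.
Compound 2 `Cc1c(O)ccc2c1[C@H](Cn1cc(-c3ccc(C(F)(F)F)cc3)nn1)[C@@]13CC(=O)[C@@](C)(CC[C@@H]21)C3`: compound 2 gives > 20000 nM, likewise a limit.
Compound 3 `C=C1C[C@]23C[C@@]1(O)CC[C@H]2c1cc(Br)c(O)c(C)c1[C@@H]3Cn1cc(-c2ccccn2)nn1`: compound 3 gives > 20000 nM, again a limit.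

Compound 1 and compound 2 share one core and differ in a single place: 4-(trifluoromethyl)phenyl in place of pyridin-2-yl on an aromatic carbon. The step that the two limits leave unreadable from compound 1 to compound 2 cannot be sized, because the limit of > 20000 nM in this assay, at which 3 of the 3 values shown sit, applies to both ends of it, so neither a gain nor a loss can be read from that pair.

Compound 3 is built on a different core; the difference between the two cores is not broken down here. Compound 4 `C=C1C[C@]23C[C@@]1(O)CC[C@H]2c1cc(Br)c(O)c(C)c1[C@@H]3Cn1cc(-c2ccc(C(F)(F)F)cc2)nn1` has not yet been measured in this assay. It stands to compound 3 exactly as compound 2 stands to compound 1: 4-(trifluoromethyl)phenyl in place of pyridin-2-yl on an aromatic carbon. The surroundings of the exchanged group are described in the same words for both pairs, so this is the same change made a second time.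

Within the data shown here, since compound 3 sits at the limit and the one earlier instance of this change, a step that the two limits leave unreadable from compound 1 to compound 2, is unreadable, compound 4 is expected to sit at that limit as well. The step that the limit leaves unreadable from compound 3 to compound 4 is therefore estimated to be within the usual scatter. Compound 4 is estimated at 40000 nM, with an expected range of 15000 nM to 120000 nM.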

Compound 4, half-maximal inhibitory concentration: 15200 nM
Estimate against measurement, compound 4: 2.6-fold (0.42 log units) above; the measured number falls inside the stated range.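

On the second core, putting 4-(trifluoromethyl)phenyl in place of pyridin-2-yl gives an at least 1.3-fold lower number from compound 3 to compound 4 (0.11 log units; that floor lies within the scatter) in this assay, so only a smallest possible size can be stated, and on its own that size does not separate the change from assay noise. Compound 3 gives > 20000 nM, which is a limit and not a number, so the true step could be larger than this floor, but the data do not show that it is. The same exchange on the core of compound 1 cannot be read, so nothing shows that the change behaves alike, or differently, on the two cores, because both ends of that pair sit at a limit, as do most of the results: the limit of > 20000 nM in this assay, at which 3 of the 4 values shown sit.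

The compounds shown leave open whether a plain phenyl ring, or a phenyl ring carrying an amine or a carboxylic acid in place of trifluoromethyl, would give a readable number on either core. Also open, going by these compounds, is which part of the difference between the two cores matters, since that difference is not split here into single changes.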